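Cyano for aminomethyl on the chain of compound 2

A few compounds are considered here, and "the series" means these few. Any claim that something is new, unique, unknown or untested is made for them only; others in the source may bear on it.

Measured compounds:
- compound 1, `C=CCN(Cc1ccc2nc(C)[nH]c(=O)c2c1)c1ccc(C(=O)N[C@@H](CCC(=O)O)C(=O)O)cc1`: 480 nM
- compound 2, `Cc1nc2ccc(CN(CCN)c3ccc(C(=O)N[C@@H](CCC(=O)O)C(=O)O)c(F)c3)cc2c(=O)[nH]1`: 11700 nM
- compound 3, `C=CCN(Cc1ccc2nc(C)[nH]c(=O)c2c1)c1ccc(C(=O)N[C@@H](CCC(=O)O)C(=O)O)cc1F`: 5160 nM

In an assay on isolated protein for inhibition of Thymidylate synthase (Mus musculus) (a lower number here means a stronger inhibitor, a higher number a weaker inhibitor), compound 2 gives the highest of the three numbers. Compound 3 gives a lower number, and compound 1 a lower number still. Within the data shown here, the one step measured between compounds that differ in one place is an 11-fold higher number from compound 1 to compound 3 (1.03 log units; beyond the scatter), a change at a different position, and it says nothing about the chain that is altered here.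

Compound 4, `Cc1nc2ccc(CN(CC#N)c3ccc(C(=O)N[C@@H](CCC(=O)O)C(=O)O)c(F)c3)cc2c(=O)[nH]1`, differs from compound 2 in one place: cyano in place of aminomethyl on a saturated chain carbon bound to a nitrogen on an aromatic ring. Among the measured compounds shown here, no measured pair shows this exchange, so there is no direct guide to its size or direction. Compound 2 and compound 3 both carry the fluoro, and their two values show compound 3 somewhat lower than compound 2 with a different group on the chain nitrogen, which suggests that the chain is not decisive. Compound 4 is therefore expected to land near compound 2, with a step of a 1.7-fold lower number from compound 2 to compound 4 (0.22 log units; within the scatter) that is estimated to stay within or just beyond the scatter; the estimated value for compound 4 is 7000 nM, between 2500 nM and 18000 nM.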

Compound 4, half-maximal inhibitory concentration: 170 nM
The estimate for compound 4 lay 41-fold (1.61 log units) above the measured number; the measured number lies below the stated range.
By their numbers in this assay, from the lowest: compound 4; then compound 1; then compound 3; then compound 2.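

Cyano in place of aminomethyl on a saturated chain carbon bound to a nitrogen on an aromatic ring gives, in this assay, a 69-fold lower number from compound 2 to compound 4 (1.84 log units; beyond the scatter), so the group on this chain can by itself move the number far beyond the scatter. Among the compounds carrying the fluoro, compound 3, with its different group on the chain nitrogen, gives 5160 nM, while compound 4 gives 170 nM, so the presence of the fluoro does not by itself hold the number high. Nothing measured here explains why this exchange has so large an effect.

On these data alone, whether the exchange would act alike in a compound without the fluoro remains open. So does how a longer chain ending in a nitrile, a carboxylic acid or a tertiary amine would behave at this place.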